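The source may hold more compounds than are shown below. What is called first, only, known or untested is meant among the compounds shown, and "the series" means these compounds.

Working notes on the series. In a functional assay on HCT-116 cells (Homo sapiens) for inhibition, read by MTT assay, with a stated time of 48 h (a higher number here means a weaker inhibitor, a lower number a stronger inhibitor), compound 2 `CCC(=O)N(Cc1ccc(OC)c(O)c1)c1cc(OC)c(OC)c(OC)c1` gives 61 nM, the lowest of the three numbers in hand. Among the compounds with values here, compound 1 `C/C=C/C(=O)N(Cc1cccc(O)c1)c1cc(OC)c(OC)c(OC)c1` gives 6700 nM and compound 3 `C/C=C/C(=O)N(Cc1cc(OC)c(OC)c(OC)c1)c1ccc(OC)c(O)c1` gives 8450 nM; both gaps to compound 2 lie beyond the scatter, and no pair of these three differs in a single place, so nothing here isolates one change. Compound 4 `COc1ccc(CN(C(=O)CN=[N+]=[N-])c2cc(OC)c(OC)c(OC)c2)cc1O` is not yet measured. It differs from compound 2 in one place: azido in place of methyl on a saturated chain carbon bound to a carbonyl carbon. Within the data shown here, no measured pair shows what this change does, so the expectation carries wide uncertainty. A moderate weakening beyond the scatter is expected, a 3.3-fold higher number from compound 2 to compound 4 (0.52 log units; beyond the scatter). For compound 4 in this assay a value of about 200 nM is expected, within the range 40 nM to 1200 nM.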

Compound 4, half-maximal inhibitory concentration: 410 nM
The estimate for compound 4 lay 2.1-fold (0.31 log units) below the measured number; the range from low to high includes it.
By their numbers in this assay, from the lowest: compound 2; then compound 4; then compounds 1 and 3 (each within the scatter of the next).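

In this assay, within the data shown here, azido in place of methyl on a saturated chain carbon bound to a carbonyl carbon gives a 6.7-fold higher number from compound 2 to compound 4 (0.83 log units; beyond the scatter), the first step that isolates a single change. This place therefore responds to the group it carries, and the response to this exchange is modest, with the azido compound still measurable in the same assay. No measurement at hand accounts for the size of this step. From the compounds shown here alone, whether an amine or a longer chain at this place would be tolerated remains open. A single step also leaves open whether the effect depends on the rest of the structure.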